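Ethyl for Methyl on the Hydroxypiperidine of Compound 2

The source may hold more compounds than are shown below. What is called first, only, known or untested is meant among the compounds shown, and "the series" means these compounds.

Measured so far in a functional assay on CHO-K1 cells for antagonist activity at melanin-concentrating hormone receptor 1 (Homo sapiens), read by inositol phosphate accumulation; on this read-out higher numbers stand for weaker inhibition and lower numbers for stronger inhibition:
compound 1 `CCC1(O)CCN(c2nc(C)c3cc(NC(=O)COc4ccc(OC(F)(F)F)cc4)ccc3n2)CC1` gives 59 nM
compound 2 `Cc1nc(N2CCC(C)(O)CC2)nc2ccc(NC(=O)COc3ccc(Cl)cc3)cc12` gives 827 nM
compound 3 `Cc1nc(N2CCN(C3CCOCC3)CC2)nc2ccc(NC(=O)COc3ccc(OC(F)(F)F)cc3)cc12` gives 31 nM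

Compound 2 stands highest of the three in this assay, beyond the scatter from both compound 1 and compound 3. Compound 4 `CCC1(O)CCN(c2nc(C)c3cc(NC(=O)COc4ccc(Cl)cc4)ccc3n2)CC1` differs from compound 2 only by methyl in place of hydrogen on a saturated chain carbon bound to a saturated ring carbon. Within the data shown here, no measured step isolates this change: compound 1 and compound 2 differ in two places at once, and the single measured step, a 1.9-fold lower number from compound 1 to compound 3 (0.28 log units; within the scatter), concerns a different part of the structure. With nothing in the data bearing directly on a methyl for hydrogen here, the step is expected to be small, a 1.2-fold lower number from compound 2 to compound 4 (0.07 log units; within the scatter), not beyond the scatter. Compound 4 is therefore estimated at 700 nM, in a range from 300 nM to 1800 nM.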

Compound 4, half-maximal inhibitory concentration: 384 nM
For compound 4 the middle estimate is 1.8-fold (0.26 log units) above the measured one; measured number inside the range.
By their numbers in this assay, from the lowest: compounds 3 and 1 (each within the scatter of the next); then compound 4; then compound 2.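

In this assay, methyl in place of hydrogen on a saturated chain carbon bound to a saturated ring carbon, which turns 4-hydroxy-4-methylpiperidin-1-yl into 4-ethyl-4-hydroxypiperidin-1-yl, gives a 2.2-fold lower number from compound 2 to compound 4 (0.33 log units; beyond the scatter), so this position responds to a single added carbon. The other end of the molecule can now be read alone: chloro in place of trifluoromethoxy on an aromatic carbon gives a 6.5-fold higher number from compound 1 to compound 4 (0.81 log units; beyond the scatter). Nothing available accounts for either step.

The compounds shown leave open whether a longer chain such as propyl on this carbon would lower the number further, and whether methyl to ethyl would move it similarly with trifluoromethoxy on the aromatic carbon.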